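Turning one hand of a stereocentre into the other

The source may report more compounds than this note shows. Statements on the series, on what has been measured and on what is new or still open speak of the compounds shown alone.

Compound 3 `CCO[C@@H](CC(=O)O)c1ccc(OCc2cccc(-c3c(C)cccc3C)c2)s1` stands apart from the other two measured compounds in a functional assay on cells for agonist activity at Free fatty acid receptor 1 (Homo sapiens), read by calcium flux; a lower number here means that less compound is needed, a higher number that more compound is needed for the effect: compound 3 gives 40100 nM, the highest of the three numbers, whereas compound 1 `Cc1cccc(C)c1-c1cccc(COc2ccc(CCC(=O)O)s2)c1` gives 32 nM and compound 2 `CCOC(CC(=O)O)c1ccc(OCc2cccc(-c3c(C)cccc3C)c2)s1` gives 57 nM. The step to compound 4 `CCO[C@H](CC(=O)O)c1ccc(OCc2cccc(-c3c(C)cccc3C)c2)s1` changes nothing in the atoms or bonds: the two compounds have the same atoms and bonds and differ only in configuration as drawn: 1 of 1 stereo elements differ; a stereocentre at a saturated chain carbon is drawn S in compound 3 and R in compound 4.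

Among the measured compounds shown here, three measured steps bear on this. The step of a 1.8-fold higher number from compound 1 to compound 2 (0.25 log units; within the scatter) shows that putting the ethoxy group onto the chain, with the new centre drawn without a configuration, changes little. The steps of a 1300-fold higher number from compound 1 to compound 3 (3.10 log units; beyond the scatter) and a 700-fold higher number from compound 2 to compound 3 (2.85 log units; beyond the scatter) show that the form drawn S is far weaker. Because (the fact that one of compounds 2 and 3 is drawn with a defined configuration and the other without, at the place where they differ), compound 2 can be read as standing for both mirror-image forms together, so its potency must come from the form drawn R, which is compound 4. The expected step of a 1300-fold lower number from compound 3 to compound 4 (3.13 log units; beyond the scatter) in this assay is therefore large and towards a lower number, back to the level of compound 2 or somewhat beyond it.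

Compound 4 is expected to give about 30 nM, within a range of 10 nM to 100 nM, resting on compound 2 having given 57 nM.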

Compound 4, half-maximal effective concentration: 50 nM
The estimate for compound 4 lay 1.7-fold (0.22 log units) below the measured number; low and high end bracket the measured number.
By their numbers in this assay, from the lowest: compounds 1, 4 and 2 (each within the scatter of the next); then compound 3.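

In this assay, the hand of this single chain carbon, which carries the ethoxy group, decides almost the whole result. The step is an 800-fold lower number from compound 3 to compound 4 (2.90 log units; beyond the scatter), and only one thing can account for it: the fact that compounds 3 and 4 differ only in the configuration as drawn. The form drawn R and the form drawn without a configuration cannot be told apart, with a 1.1-fold lower number from compound 2 to compound 4 (0.06 log units; within the scatter), which turns the earlier inference about where the potency of compound 2 lies into a direct measurement of a single drawn form: the fact that one of compounds 2 and 4 is drawn with a defined configuration and the other without, at the place where they differ. Ethoxy in place of hydrogen is also tolerated at this position when drawn R, since a 1.6-fold higher number from compound 1 to compound 4 (0.19 log units; within the scatter) separates this form from the compound with no ethoxy group, so the large loss seen earlier belongs to the form drawn S and not to the group as such.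

The compounds shown leave open whether a methoxy group, a hydroxyl group or a longer chain such as propoxy on this same carbon would separate the two hands as sharply as ethoxy does. They also say nothing about why the form drawn S needs so much more compound for the effect.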